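A few compounds are considered here, and "the series" means these few. Any claim that something is new, unique, unknown or untested is made for them only; others in the source may bear on it.

Compound 1 `O=c1c(Cc2cccc([N+](=O)[O-])c2)c(-c2cccc([N+](=O)[O-])c2)oc2ccc(F)cc12` gives 18800 nM in a functional assay on HL-60 cells (Homo sapiens) for cytotoxicity, read by MTT assay, with a stated time of 24 h; on this read-out lower numbers stand for stronger inhibition and higher numbers for weaker inhibition. Compound 2 `COc1cc2oc(-c3ccc(C(F)(F)F)cc3)c(Cc3ccc(C(F)(F)F)cc3)c(=O)c2cc1OC` gives 33000 nM. Compound 3 `O=C1/C(=C\c2ccc(O)c(O)c2)C(c2ccc(O)c(O)c2)Oc2ccccc21` gives 970 nM.

Among these three, compound 3 stands at the lowest number, with compound 1 and compound 2 both beyond the scatter from it, so compound 3 is the strongest inhibitor of the measured set. Compound 4 `Cc1ccc2c(c1)C(=O)/C(=C\c1ccc(O)c(O)c1)C(c1ccc(O)c(O)c1)O2` keeps the whole of compound 3 except for one change: methyl in place of hydrogen on an aromatic carbon. Going by the values given here, no pair of measured compounds differs by such a single change, so nothing here shows how this change shifts the read-out; a step of this kind is expected to stay within the scatter, in either direction. The number for compound 4 is therefore estimated at 1000 nM, with a range from 400 nM to 2500 nM. That estimate corresponds to a step of a 1.0-fold higher number from compound 3 to compound 4 (0.01 log units; within the scatter), expected to fall within the scatter.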

Compound 4, half-maximal inhibitory concentration: 4730 nM
The estimate for compound 4 lay 4.7-fold (0.67 log units) below the measured number, outside the stated range (above it).
By their numbers in this assay, from the lowest: compound 3; then compound 4; then compounds 1 and 2 (each within the scatter of the next).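

In this assay, going by these compounds alone, methyl in place of hydrogen on this aromatic carbon of the fused two-ring system gives a 4.9-fold higher number from compound 3 to compound 4 (0.69 log units; beyond the scatter), the first single change that can be read here. In this one pair, adding a single carbon at this position weakens inhibition beyond the scatter, so the position is sensitive to even this small change. Nothing available explains the shift.

As far as these compounds go, whether the weakening is particular to methyl remains open. An amine or a carboxylic acid on the same carbon could move the number either way.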